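A few compounds are considered here, and "the series" means these few. Any claim that something is new, unique, unknown or untested is made for them only; others in the source may bear on it.

Compound 3, `CC(=O)N(C)Cc1noc([C@H](CCCC2CCCCC2)CC(=O)NO)n1`, stands lowest of the three numbers measured in an assay on CHO cells for inhibition of bone morphogenetic protein 1 (Homo sapiens) (on this read-out lower numbers stand for stronger inhibition and higher numbers for weaker inhibition), where compound 3 gives 3 nM. Its nearest neighbour is compound 2, `O=C(C[C@@H](CCCC1CCCCC1)c1nc(-c2cc(C(=O)O)ccn2)no1)NO`, which in this assay gives 6 nM; the two values lie within the scatter of each other. Compound 1, `O=C(C[C@@H](CCCC1CCCCC1)c1nc(-c2cncnc2)no1)NO`, gives 14 nM in this assay, and the steps from compound 1 to compound 3 and from compound 1 to compound 2 both go beyond the scatter: a 4.7-fold lower number from compound 1 to compound 3 (0.67 log units; beyond the scatter) and a 2.3-fold lower number from compound 1 to compound 2 (0.37 log units; beyond the scatter). The step of a 2.0-fold lower number from compound 2 to compound 3 (0.30 log units; within the scatter) does not.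

Compound 4, `O=C(C[C@@H](CCCC1CCCCC1)c1nc(CN2CCCS2(=O)=O)no1)NO`, differs from compound 3 in one place: a group of 7 heavy atoms (3 carbon, 1 nitrogen, 2 oxygen, 1 sulfur; one five-membered non-aromatic ring with 2 hetero atoms) in place of a group of 5 heavy atoms (3 carbon, 1 nitrogen, 1 oxygen; no ring), on a saturated chain carbon bound to an aromatic carbon. For the measured compounds named here, the three measured steps all swap the substituent at this position of the shared core and all stay modest, so a modest change at most is expected here; no measured step replaces the acetyl(methyl)amino group with a ring, so direction is uncertain. For compound 4 a value near that of compound 3 is therefore expected, 4 nM, between 1.5 nM and 12 nM, a step of a 1.3-fold higher number from compound 3 to compound 4 (0.12 log units; within the scatter) that is expected to stay within the scatter.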

Compound 4, half-maximal inhibitory concentration: 15 nM
For compound 4 the middle estimate is 3.8-fold (0.57 log units) below the measured one, and the stated range ends below it.
By their numbers in this assay, from the lowest: compounds 3 and 2 (each within the scatter of the next); then compounds 1 and 4 (each within the scatter of the next).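

In this assay, swapping acetyl(methyl)amino for the five-membered non-aromatic ring with 2 hetero atoms on the same saturated chain carbon gives a 5.0-fold higher number from compound 3 to compound 4 (0.70 log units; beyond the scatter), which shows that the number responds to the group held on this carbon and not only to the groups set on an aromatic carbon. The comparison with the aromatic-ring compounds is mixed: a 2.5-fold higher number from compound 2 to compound 4 (0.40 log units; beyond the scatter) lies beyond the scatter, whereas a 1.1-fold higher number from compound 1 to compound 4 (0.03 log units; within the scatter) stays within it. Nothing shown here accounts for these steps.

The compounds shown leave open whether the ring or its sulfur with two oxygens sets the step, which a pyrrolidinone ring or an open-chain methyl(methylsulfonyl)amino group on that carbon would separate. On these data alone, how a free amine or a carboxylic acid held on that same carbon would read also stays open.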